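The compounds below may be only part of what the source reports. "The series", "measured", "known", "first", "only" and "open" are said of these compounds alone.

Of the compounds shown here, three have so far been tested in a toxicity assay on THP-1 cells (Homo sapiens) for inhibition; on this read-out higher numbers stand for lower toxicity in this test and lower numbers for higher toxicity in this test. Compound 1 `Cn1c(-c2ccccc2F)cnc1NC(=O)c1ccc(F)cc1` carries a fluoro group on one of its aromatic rings. In this assay compound 1 reaches only a limit of the test, > 100000 nM. Compound 2 `Cc1ccccc1-c1cnc(NC(=O)c2ccc(F)cc2)n1C` is related to it by the change (fluoro in place of methyl on an aromatic carbon). In this assay compound 2 likewise reaches only a limit, > 50000 nM. The step that the two limits leave unreadable from compound 2 to compound 1 therefore cannot be sized, because the two values sit at the limit of > 50000 nM in this assay, at which 1 of the 3 values shown sits, and (the limit of > 100000 nM in this assay, at which 2 of the 3 values shown sit).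

Compound 3 `COc1ccc(-c2cnc(NC(=O)c3cccc(C)c3)n2C)cc1` has a different core from compound 2; the difference between the two cores is not broken down here. In this assay compound 3 also gives only a limit, > 100000 nM. Compound 4 `COc1ccc(-c2cnc(NC(=O)c3cccc(F)c3)n2C)cc1`, not yet measured, arises from compound 3 through (fluoro in place of methyl on an aromatic carbon). This is the same kind of change as from compound 2 to compound 1, but there the group sat ortho to a large group, here meta to a large group.

With no readable earlier step, the step from compound 3 to compound 4 is expected to be a number no higher from compound 3 to compound 4 (the limit leaves the size open). For compound 4 the estimated value is 100000 nM, spanning 50000 nM to 200000 nM, and most likely only a limit will again be reported.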

Compound 4, half-maximal cytotoxic concentration: > 100000 nM
Compound 4: only a limit was reported; the forecaster's own chance of this, stated with the estimate: 85%; the middle value sits exactly at the limit.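

In this assay compound 3 and compound 4 both end at a limit of the test, so no size can be read for the change from 3-methylphenyl to 3-fluorophenyl: the limit of > 100000 nM in this assay, at which 3 of the 4 values shown sit.

The compounds shown leave open what the actual half-maximal cytotoxic concentration of each one is, and whether fluoro in place of methyl changes it at all.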